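This account rests on a few compounds, and the source may have more. Where it says the series, first, only, none or still open, it means among the compounds named here.

Working notes on the series. Compound 1 `O=S(=O)(Nc1ccc2oc(-c3ccccc3)nc2c1)c1ccc(Cl)cc1` and compound 2 `Cc1cccc(S(=O)(=O)Nc2ccc3oc(-c4ccccc4)nc3c2)c1` share one core; compound 3 `Cc1cccc(S(=O)(=O)Nc2ccc(-c3nc4ccccc4o3)cc2)c1` and compound 4 `O=S(=O)(Nc1ccc(-c2nc3ccccc3o2)cc1)c1ccc(Cl)cc1` share a second core built from the same atoms joined differently. The difference between the two cores is not broken down here.

In an ADME assay on HEK293 cells (Homo sapiens) for cytotoxicity, read by resazurin assay, with a stated time of 48 h (on this read-out higher numbers stand for lower toxicity in this test and lower numbers for higher toxicity in this test), compound 2 gives 69000 nM. In this assay compound 1 gives 65000 nM. The change from compound 2 to compound 1 is 4-chlorophenyl in place of 3-methylphenyl on a sulfonyl sulfur, and the step it made was a 1.1-fold lower number from compound 2 to compound 1 (0.03 log units; within the scatter). Both values sit in the same band, so no ordering between compound 1 and compound 2 is drawn.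

For compound 3 the record in this assay is a limit and not a number: compound 3 stands at > 100000 nM. This value sits at the limit of > 100000 nM in this assay, at which 1 of the 3 values shown sits, the ceiling of what the test resolves.

Compound 4 carries the same kind of change relative to compound 3, namely (4-chlorophenyl in place of 3-methylphenyl on a sulfonyl sulfur), and the place, on a sulfonyl sulfur whose other neighbour is the sulfonamide nitrogen, reads the same in both pairs. The step from compound 3 to compound 4 is expected to be a number no higher from compound 3 to compound 4 (the limit leaves the size open). This expectation rests on the measured pair, where compound 2 to compound 1 gave a 1.1-fold lower number from compound 2 to compound 1 (0.03 log units; within the scatter), a step inside the scatter, and on compound 3 already standing at > 100000 nM, so compound 4 is expected to remain at or near the ceiling.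

In this assay compound 4 is estimated at 100000 nM, with a range from 50000 nM to 200000 nM, and a limit rather than a number is the likelier outcome.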

Compound 4, half-maximal cytotoxic concentration: > 100000 nM
Compound 4 gave a limit, no number (the forecaster's own chance of this, stated with the estimate: 70%); the middle value lies on the limit itself.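

In this assay compound 4 gives > 100000 nM, which is a limit and not a number. For the compounds shown here, compound 3 also stands at a limit in this test, so no step between compound 3 and compound 4 can be read: the limit of > 100000 nM in this assay, at which 2 of the 4 values shown sit. The compounds shown leave open whether 4-chlorophenyl in place of 3-methylphenyl on a sulfonyl sulfur changes the read-out at all on the core of compound 3.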